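The source may report more compounds than this note shows. Statements on the series, on what has been measured and on what is new or still open speak of the compounds shown alone.

Going by the values given here, in a functional assay on the whole organism for inhibition, with Brassica rapa subsp. chinensis as the target, with a stated time of 3 days, tested at 100 ppm (a lower number here means less inhibition of growth, a higher number more inhibition of growth at the concentration tested), compound 1 (`CCCCCNC(=O)/C=C/c1ccccc1`) gives 60%, the highest of the three numbers measured so far. Compound 3 (`CCCCCCCCNC(=O)/C=C/c1ccccc1`) gives 34%, and compound 2 (`CCCCCCCCCCNC(=O)/C=C/c1ccccc1`) gives 10%. The next compound to be read is compound 4 (`CC(C)CNC(=O)/C=C/c1ccccc1`). It departs from compound 1 by one change: isopropyl in place of butyl on a saturated chain carbon bound to an amide-type nitrogen. This is isopropyl in place of butyl on a saturated chain carbon bound to an amide-type nitrogen, which, cut one bond further out, reads pentyl to isobutyl.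

Among the compounds with values here, three measured steps bear on this change, and all of them concern lengthening the chain. The modest step of a number 26 percentage points lower from compound 1 to compound 3 (beyond the scatter) and the large step of a number 50 percentage points lower from compound 1 to compound 2 (beyond the scatter) point the same way, and the modest step of a number 24 percentage points higher from compound 2 to compound 3 (beyond the scatter) agrees with them. Across these three compounds the number falls as the chain grows, and none goes against that. Within the data shown here, the change to compound 4 runs the other way, but no measured compound carries isobutyl, so the data offer no direct guide to it. Only a small rise in this assay is therefore expected, one that may not clear the scatter. The expected step is a number 4 percentage points higher from compound 1 to compound 4 (within the scatter). For compound 4 the estimated value is 64%, with an expected range of 44% to 82%.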

Compound 4, percent growth inhibition at one concentration: 34%
Estimate against measurement, compound 4: 30 percentage points above; the measured number lies below the stated range.
By their numbers in this assay, from the lowest: compound 2; then compounds 3 and 4 (each within the scatter of the next); then compound 1.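

In this assay, the change from the pentyl chain of compound 1 to the isobutyl chain of compound 4 gives a number 26 percentage points lower from compound 1 to compound 4 (beyond the scatter), so this position does not reward every move away from the longer chains. Among compounds 1, 2 and 3, the number fell as the straight chain grew, but compound 4 goes against any reading in which simply having fewer carbon atoms at this place raises the number: isopropyl enters with fewer carbon atoms than the butyl it replaces, yet the number drops. Compound 1 now stands highest of the four, its steps to all the others lying beyond the scatter, and nothing available here accounts for the effect of this branched chain on growth inhibition.

Going by these compounds, what stays open is how a straight butyl or propyl chain would read at this place, and with it whether the drop goes with the branch or with the shorter length. Also open, on these data alone, is whether a hexyl chain would fall between compounds 1 and 3, and how a hydroxyl or an amine at the end of the pentyl chain would read.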